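Swapping the aryl group on a quinone-like core

This account rests on a few compounds, and the source may have more. Where it says the series, first, only, none or still open, it means among the compounds named here.

Measured so far:
compound 1 `CCc1ccc(NC2=CC(=O)c3c(nc4n3[C@H]3OC[C@@H](O)[C@H]3OC4)C2=O)cc1` — 1110 nM
compound 2 `CCOc1ccccc1NC1=CC(=O)c2nc3n(c2C1=O)[C@H]1OC[C@@H](O)[C@H]1OC3` — 2450 nM
compound 3 `O=C1C=C(Nc2ccc(I)cc2)C(=O)c2c1nc1n2[C@H]2OC[C@@H](O)[C@H]2OC1` — 1400 nM

In a functional assay on MGC-803 cells (Homo sapiens) for inhibition, read by sulforhodamine B assay (a lower number here means a stronger inhibitor, a higher number a weaker inhibitor), compound 1 gives the lowest of the three numbers; compound 3 sits within the scatter of it, while compound 2 lies beyond it. Compound 4 `CCOc1ccccc1NC1=CC(=O)c2c(nc3n2[C@H]2OC[C@@H](O)[C@H]2OC3)C1=O` keeps the core of compound 1 and differs only by 2-ethoxyphenyl in place of 4-ethylphenyl on an amine nitrogen. Among the measured compounds shown here, no measured step makes this exact change on this core. The nearest guide is a 1.8-fold lower number from compound 2 to compound 3 (0.24 log units; within the scatter), on the other core, which stayed within the scatter, and compounds 1 and 3 show values within the scatter of each other. A step of similar size is therefore expected, a 1.6-fold higher number from compound 1 to compound 4 (0.21 log units; within the scatter), with compound 4 estimated at 1800 nM (range 800 nM to 4000 nM).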

Compound 4, half-maximal inhibitory concentration: 2830 nM
Estimate against measurement, compound 4: 1.6-fold (0.20 log units) below, within the range that was stated.
By their numbers in this assay, from the lowest: compounds 1, 3, 2 and 4 (each within the scatter of the next, the first and the last beyond it).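

In this assay the aryl group on the amine nitrogen now makes a difference larger than the usual scatter: 2-ethoxyphenyl in place of 4-ethylphenyl gives a 2.5-fold higher number from compound 1 to compound 4 (0.41 log units; beyond the scatter) on the core of compound 1. Among the compounds shown here, the only earlier step, from 2-ethoxyphenyl to 4-iodophenyl on the other core, stayed within the scatter, so this is the first sign, still a modest one, that the choice of aryl group matters. Nothing available explains this difference.

Still open, from the compounds shown here alone, is how a plain phenyl or a pyridine ring would behave on this nitrogen. A carboxylic acid or an amine on the aryl ring is equally unresolved.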